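From compound 3 to its methyl analogue, compound 4

The source may report more compounds than this note shows. Statements on the series, on what has been measured and on what is new or still open speak of the compounds shown alone.

Measured in an ADME assay on HEK-293T cells (Homo sapiens) for cytotoxicity, read by MTT assay, with a stated time of 48 h; a higher number here means that more compound is tolerated, a lower number that less compound is tolerated:
Compound 1 `COc1ccc2c(c1)c(C1CC(c3ccccc3)=NN1C(=O)c1cccnc1)cn2C`: > 300000 nM, a limit of the assay
Compound 2 `COc1ccc2c(c1)c(C1CC(c3ccc(Br)cc3)=NN1C(=O)c1ccc(OC)nc1)cn2C`: > 300000 nM, a limit of the assay
Compound 3 `COc1cccc(C2=NN(C(=O)c3cccnc3)C(c3cn(C)c4ccc(OC)cc34)C2)c1`: 125000 nM

Compound 3, at 125000 nM, is the only one of the three with an actual number in this assay. The other two stand at the limit of > 300000 nM in this assay, at which 2 of the 3 values shown sit.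

Compound 4 `COc1cccc(C2=NN(C(=O)c3ccc(C)nc3)C(c3cn(C)c4ccc(OC)cc34)C2)c1` keeps all of compound 3 except for one change: methyl in place of hydrogen on an aromatic carbon, next to the ring nitrogen, which turns pyridin-3-yl into 6-methylpyridin-3-yl (methyl in place of hydrogen on an aromatic carbon).

Among the measured compounds shown here, only one measured step bears on this, and only loosely: an at least 2.4-fold lower number from compound 1 to compound 3 (0.38 log units; beyond the scatter). That step also replaced a hydrogen on an aromatic carbon, with methoxy rather than methyl, but in another part of the molecule. With this single step as a guide, the change in this assay is expected to be no larger than that one. A slightly lower number is the likelier direction, and a shift within the scatter is quite possible. The expected step is a 1.1-fold lower number from compound 3 to compound 4 (0.06 log units; within the scatter). For compound 4 the estimate is 110000 nM, with an expected range from 50000 nM to 250000 nM.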

Compound 4, half-maximal cytotoxic concentration: > 300000 nM
Compound 4: a limit, no number (the forecaster's own chance of this, stated with the estimate: 20%); middle value at least 2.7-fold (0.43 log units) from the limit.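

In this assay, compound 4 gives > 300000 nM, which is a limit of the assay and not a number. This is the first change shown in one place on the pyridin-3-yl ring, at an aromatic carbon next to the ring nitrogen, and it gives an at least 2.4-fold higher number from compound 3 to compound 4 (0.38 log units; beyond the scatter), the opposite direction to the only earlier step, an at least 2.4-fold lower number from compound 1 to compound 3 (0.38 log units; beyond the scatter), which put a methoxy group elsewhere in the molecule. The single added methyl is thus enough to take the compound from a measured value back to the limit, which leaves compound 3 as the only compound with an actual number: the limit of > 300000 nM in this assay, at which 3 of the 4 values shown sit.

As far as these compounds go, since compound 4 sits at a limit, the true size of the step stays unknown, and it cannot be said how far the tolerated concentration lies beyond what the assay reads. From the compounds shown here alone, it also remains open whether the same carbon would respond in the same way to an ethyl group, an amine or a carboxylic acid, and whether methyl there would have any visible effect in a compound that lacks the methoxy group on the phenyl ring.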